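Thiophen-3-yl in Place of Trifluoromethyl: An Expected Inhibition

A few compounds are considered here, and "the series" means these few. Any claim that something is new, unique, unknown or untested is made for them only; others in the source may bear on it.

Measured compounds:
compound 1, `Cc1cc(Nc2cc(Cl)cc(Cl)c2)nc(N)n1`, 27%
compound 2, `Cc1cc(Nc2cc(Cl)cc(Br)c2)nc(N)n1`, 33%
compound 3, `Cc1cc(Nc2cc(Cl)cc(C(F)(F)F)c2)nc(N)n1`, 39%

In an assay on cells for inhibition of S-adenosylmethionine decarboxylase proenzyme (Homo sapiens), read by mass spectrometry, at pH 7.2, tested at 180 uM (on this read-out lower numbers stand for less inhibition and higher numbers for more inhibition at the one concentration tested (going by the name of the read-out)), compound 3 has the highest of the three numbers: the step of a number 12 percentage points higher from compound 1 to compound 3 (beyond the scatter) lies beyond the scatter, while a number 6 percentage points higher from compound 2 to compound 3 (within the scatter) does not, so compound 3 and compound 2 cannot be ranked against each other. Compound 4, `Cc1cc(Nc2cc(Cl)cc(-c3ccsc3)c2)nc(N)n1`, differs from compound 3 in one place: thiophen-3-yl in place of trifluoromethyl on an aromatic carbon. The measured steps at this same aromatic carbon, a number 6 percentage points higher from compound 1 to compound 2 (within the scatter), a number 12 percentage points higher from compound 1 to compound 3 (beyond the scatter) and a number 6 percentage points higher from compound 2 to compound 3 (within the scatter), are all small and all upward or flat, yet none brings in a ring, so they bear on the new change only loosely. A step within the scatter, a number 3 percentage points higher from compound 3 to compound 4 (within the scatter), is therefore expected. Compound 4 is estimated at 42%, with a range of 25% to 60%.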

Compound 4, a percentage reported as inhibition, at one concentration (the size of the read-out at that concentration, not a potency): 30%
Estimate against measurement, compound 4: 12 percentage points above; the range from low to high includes it.
By their numbers in this assay, from the lowest: compounds 1, 4, 2 and 3 (each within the scatter of the next, the first and the last beyond it).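

A whole ring can stand at this aromatic carbon in place of a single atom or a small group, and in this assay the number stays close: the steps of a number 9 percentage points lower from compound 3 to compound 4 (within the scatter) and a number 3 percentage points lower from compound 2 to compound 4 (within the scatter) and a number 3 percentage points higher from compound 1 to compound 4 (within the scatter) all leave thiophen-3-yl unranked against trifluoromethyl, bromo and chloro. No measurement shown gives a reason for this result. Still open, from the compounds shown here alone, is whether an amine, a carboxylic acid or a longer chain at this carbon would bring a step beyond the scatter.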